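Dimethylamino to Octylsulfanyl: Expected Tolerance of Compound 4

This account rests on a few compounds, and the source may have more. Where it says the series, first, only, none or still open, it means among the compounds named here.

In an ADME assay on BCBL1 cells (Homo sapiens) for cytotoxicity, with a stated time of 7 days (a higher number here means that more compound is tolerated, a lower number that less compound is tolerated), compound 3 `CN(C)c1nc(N)nc2c1ncn2/C=C1/CC1(CO)CO` gives only a limit, > 20000 nM. Compound 1 `C=CCOc1nc(N)nc2c1ncn2/C=C1/CC1(CO)CO` likewise gives a limit, > 20000 nM. Compound 2 `CCOc1nc(N)nc2c1ncn2/C=C1/CC1(CO)CO` also sits at a limit, > 20000 nM. Thus (the limit of > 20000 nM in this assay, at which 3 of the 3 values shown sit), and the steps a step that the two limits leave unreadable from compound 1 to compound 2, a step that the two limits leave unreadable from compound 1 to compound 3 and a step that the two limits leave unreadable from compound 2 to compound 3 have no readable size. Compound 4 `CCCCCCCCSc1nc(N)nc2c1ncn2/C=C1/CC1(CO)CO` differs from compound 3 by octylsulfanyl in place of dimethylamino on an aromatic carbon. Going by the values given here, none of the measured steps has a readable size that could bear on this change, since all three measured compounds share the same limit. The expectation is therefore that compound 4 remains near that limit, with no step beyond the scatter, the expected step being a number no higher from compound 3 to compound 4 (the limit leaves the size open). The estimate for compound 4 in this assay is 20000 nM, ranging from 4000 nM to 60000 nM.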

Compound 4, half-maximal cytotoxic concentration: > 20000 nM
Compound 4: only a limit was reported; the forecaster's own chance of this, stated with the estimate: 60%; the middle value sits exactly at the limit.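

In this assay, going by these compounds alone, compound 4 gives only the limit > 20000 nM and no step to it from compound 1, compound 2 or compound 3 can be read: the limit of > 20000 nM in this assay, at which 4 of the 4 values shown sit. The compounds shown leave open at what concentration any of the four becomes cytotoxic, and whether octylsulfanyl, dimethylamino, ethoxy and allyloxy differ at all in this read-out.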